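Swapping a chlorophenyl for a pyridyl ring on a thiazole core

The source may hold more compounds than are shown below. What is called first, only, known or untested is meant among the compounds shown, and "the series" means these compounds.

Measured so far:
Compound 1, `Nc1nc(N2CCN(C(=O)COc3ccc(Cl)cc3)CC2)c2nc(Cc3ccc(F)cc3)sc2n1`, 700 nM
Compound 2, `Nc1nc(N2CCN(C(=O)COc3ccc(Cl)cc3)CC2)c2nc(-c3ccc(Cl)cc3)sc2n1`, 270 nM

Both compounds were tested in a functional assay on cells (Lymphocyte, Homo sapiens); on this read-out higher numbers stand for weaker inhibition and lower numbers for stronger inhibition. Compound 2 carries the lowest of the two numbers; its nearest neighbour is compound 1, and the step of a 2.6-fold lower number from compound 1 to compound 2 (0.41 log units; beyond the scatter) shows that this gap is beyond the scatter, though modest in size. Compound 3, `Nc1nc(N2CCN(C(=O)COc3ccc(Cl)cc3)CC2)c2nc(-c3cccnc3)sc2n1`, has not yet been measured. Its difference from compound 2 is pyridin-3-yl in place of 4-chlorophenyl on an aromatic carbon. Going by the values given here, the only step available, from compound 1 to compound 2, concerns a change at the same place on the shared core, but it exchanged a benzyl group for a directly attached chlorophenyl ring, so it gives only indirect guidance for swapping the chlorophenyl for a pyridin-3-yl. Among the compounds with values here, with no closer precedent, a step of roughly the same modest size as that one is expected, in the direction of a higher number, with the possibility that it stays within the scatter. Compound 3 is therefore estimated to give 600 nM, with a range from 200 nM to 1800 nM, which corresponds to the expected step of a 2.2-fold higher number from compound 2 to compound 3 (0.35 log units; beyond the scatter).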

Compound 3, half-maximal inhibitory concentration: 50 nM
The estimate for compound 3 lay 12-fold (1.08 log units) above the measured number; measured number outside the range, below it.
By their numbers in this assay, from the lowest: compound 3; then compound 2; then compound 1.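

This position on the five-membered aromatic ring with 1 nitrogen and 1 sulfur tolerates more than a carbon-only aryl ring: in this assay, pyridin-3-yl gives a 5.4-fold lower number from compound 2 to compound 3 (0.73 log units; beyond the scatter), so a ring holding a nitrogen atom is clearly better here than 4-chlorophenyl. The earlier compounds had shown only a change from 4-fluorobenzyl to 4-chlorophenyl, whereas the new ring gives a 14-fold lower number from compound 1 to compound 3 (1.15 log units; beyond the scatter) and places compound 3 lowest of the three, with each gap beyond the usual scatter. No measurement here explains why the pyridin-3-yl ring does better.

The change removes the chlorine atom and brings in a ring nitrogen with a hydrogen-bond acceptor at the same time, so these two effects cannot be told apart, and an unsubstituted phenyl ring would be needed to separate them. From the compounds shown here alone, it also remains open whether the placement of the nitrogen within the ring matters, which pyridin-2-yl and pyridin-4-yl would test at this same position.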